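The source may hold more compounds than are shown below. What is called first, only, known or untested is meant among the compounds shown, and "the series" means these compounds.

Compound 1 `CC(C)c1c(C(=O)NCc2ccccc2)nn(-c2ccc(F)cc2)c1OC[C@@H](O)C[C@@H](O)CC(=O)O` carries a benzylamino group on the carbonyl carbon of the shared core. All results here come from a functional assay on L6 cells (Rattus norvegicus) for inhibition; on this read-out higher numbers stand for weaker inhibition and lower numbers for stronger inhibition. In this assay compound 1 gives 880 nM. Compound 2 `CC(C)c1c(C(=O)N2CCCCC2)nn(-c2ccc(F)cc2)c1OC[C@@H](O)C[C@@H](O)CC(=O)O` has a piperidin-1-yl group in that position instead, and in this assay compound 2 gives 32200 nM, which is the highest number among the two compounds with a result and thus the weakest inhibition seen so far. The step of a 37-fold higher number from compound 1 to compound 2 (1.56 log units; beyond the scatter) shows that swapping the benzylamino group for the piperidin-1-yl group costs a great deal of inhibition. Compound 3 `CC(C)c1c(C(=O)NCc2ccc(Cl)cc2)nn(-c2ccc(F)cc2)c1OC[C@@H](O)C[C@@H](O)CC(=O)O` has a chlorine-bearing benzylamino group, and in this assay compound 3 gives "not determined" (no result reported), so no result is available for it.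

Compound 4 `CC(C)c1c(C(=O)N(C)Cc2ccc(F)c(F)c2)nn(-c2ccc(F)cc2)c1OC[C@@H](O)C[C@@H](O)CC(=O)O` differs from compound 2 as follows: (3,4-difluorobenzyl)(methyl)amino in place of piperidin-1-yl on a carbonyl carbon. This change brings back a benzyl group on the amide nitrogen, now with a methyl group and two fluorine atoms added, so it lies between compound 2 and compound 1 in structure. For the measured compounds named here, only the step from compound 1 to compound 2 bears on it, and it was large in favour of the benzyl amide. Going by the values given here, compound 4 is therefore expected to regain much of that inhibition, with a step of about an 11-fold lower number from compound 2 to compound 4 (1.03 log units; beyond the scatter), though the added methyl group has no precedent here. The estimated value for compound 4 in this assay is 3000 nM, within a range of 700 nM to 13000 nM.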

Compound 4, half-maximal inhibitory concentration: 4570 nM
Beside the measured number, compound 4's estimate is 1.5-fold (0.18 log units) below it, and the stated range covers the measured number.
By their numbers in this assay, from the lowest: compound 1; then compound 4; then compound 2.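

Putting a benzyl group back on the amide nitrogen, as (3,4-difluorobenzyl)(methyl)amino in place of piperidin-1-yl, gives a 7.0-fold lower number from compound 2 to compound 4 (0.85 log units; beyond the scatter) in this assay and so shows that much of the inhibition lost with the piperidin-1-yl group can be won back on this carbonyl carbon. The recovery is only partial, since the same group in place of benzylamino gives a 5.2-fold higher number from compound 1 to compound 4 (0.72 log units; beyond the scatter) and leaves compound 1 with the strongest inhibition of the three compounds that have a number, so a benzyl group alone does not settle the result here. Nothing available explains why either change moves the number as it does.

For the compounds shown here, the step from compound 1 to compound 4 adds a methyl group and two fluorine atoms together, so their separate contributions stay unknown; (benzyl)(methyl)amino and 3,4-difluorobenzylamino would each carry only one of these changes. On these data alone, it also remains open whether the benzyl ring itself is needed or whether a longer chain, such as 2-phenylethylamino, would serve as well on this carbonyl carbon.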